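Swapping the aryl group on the ring nitrogen for pyridinylmethyl

The source may report more compounds than this note shows. Statements on the series, on what has been measured and on what is new or still open speak of the compounds shown alone.

Measured so far:
compound 1 `Nc1ccccc1NC(=O)c1ccc(CSC(=S)N2CCN(Cc3ccccn3)CC2)cc1` gives 23.4%
compound 2 `Nc1ccccc1NC(=O)c1ccc(CSC(=S)N2CCN(c3ccc(F)cc3)CC2)cc1` gives 18.8%
compound 3 `N#Cc1ccc(N2CCN(C(=S)SCc3ccc(C(=O)Nc4ccccc4N)cc3)CC2)cc1` gives 34.5%

All three share one core and differ only in the group on an amine nitrogen in a ring. In a functional assay on MGC-803 cells (Homo sapiens) for antiproliferative activity, read by CCK-8 assay, with a stated time of 72 h, tested at 2 uM (on this read-out higher numbers stand for a stronger effect at the one concentration tested and lower numbers for a weaker effect), compound 3 holds the highest of the three numbers; the nearest is compound 1 a number 11.1 percentage points higher from compound 1 to compound 3 (beyond the scatter), the furthest compound 2 a number 15.7 percentage points higher from compound 2 to compound 3 (beyond the scatter), while the gap between compounds 1 and 2 is small a number 4.6 percentage points lower from compound 1 to compound 2 (within the scatter).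

Compound 4 `Nc1ccccc1NC(=O)c1ccc(CSC(=S)N2CCN(Cc3ccncc3)CC2)cc1` is the next step: (pyridin-4-yl)methyl in place of 4-cyanophenyl on an amine nitrogen in a ring. Among the measured compounds shown here, the step that bears on it most is the one from compound 1 to compound 3, where (pyridin-2-yl)methyl was replaced by 4-cyanophenyl and the number rose modestly. Undoing a change of that kind, now with the (pyridin-4-yl)methyl group, is expected to lower the read-out by roughly the same amount, so a downward step a number 10.5 percentage points lower from compound 3 to compound 4 (beyond the scatter) is estimated. For compound 4 the expected value is 24%, within a range from 12% to 38%.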

Compound 4, a percentage reported as inhibition, at one concentration (the size of the read-out at that concentration, not a potency): 18.4%
For compound 4 the middle estimate is 5.6 percentage points above the measured one; the range from low to high includes it.
By their numbers in this assay, from the lowest: compounds 4, 2 and 1 (each within the scatter of the next); then compound 3.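

In this assay, the position of the ring nitrogen in the pyridine of this group makes no difference beyond the scatter: pyridin-4-yl and pyridin-2-yl on the saturated chain carbon cannot be told apart (a number 5 percentage points lower from compound 1 to compound 4 (within the scatter)). (Pyridin-4-yl)methyl also cannot be told apart from 4-fluorophenyl (a number 0.4 percentage points lower from compound 2 to compound 4 (within the scatter)), but it falls clearly short of 4-cyanophenyl (a number 16.1 percentage points lower from compound 3 to compound 4 (beyond the scatter)). Of the four groups on this amine nitrogen, only 4-cyanophenyl therefore stands apart, and nothing available explains why.

The step from 4-cyanophenyl to (pyridin-4-yl)methyl changes both the ring and its link to the nitrogen, so it cannot show which of the two matters. A 4-cyanobenzyl group would separate them, and (pyridin-3-yl)methyl would complete the pyridine series.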